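A few compounds are considered here, and "the series" means these few. Any claim that something is new, unique, unknown or untested is made for them only; others in the source may bear on it.

Going by these compounds, the series consists of three measured compounds and one whose value is still open. Compound 1 `COc1ccccc1/C=C/C[C@H]1C[C@@H]([C@@H](O)c2ccccc2)CO[C@@H]1c1ccccc1` has the lowest number recorded so far in a functional assay on HeLa cells (Homo sapiens) for cytotoxicity, read by WST assay, with a stated time of 48 h (on this read-out lower numbers stand for stronger inhibition and higher numbers for weaker inhibition), giving 14700 nM. Compound 3 `COc1ccc(/C=C/C[C@@H]2C[C@@H]([C@@H](O)c3ccccc3)CO[C@H]2c2ccc(OC)c(OC)c2)cc1OC` gives 16800 nM in this assay, a gap to compound 1 that lies within the scatter of repeated measurements. Compound 2 `COc1ccc(CCC[C@H]2C[C@@H]([C@@H](O)c3ccc(OC)c(OC)c3)CO[C@@H]2c2ccc(OC)c(OC)c2)cc1OC` gives 37700 nM in this assay, a number that stands higher than that of compound 1 by a margin beyond the scatter. No pair among these three differs in only one place, so no single structural step can be read from the measured set.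

The step from compound 1 leads to compound 4 `Oc1ccc(/C=C/C[C@H]2C[C@@H]([C@@H](O)c3ccccc3)CO[C@@H]2c2ccccc2)cc1`. The change is 4-hydroxyphenyl in place of 2-methoxyphenyl on a double-bonded chain carbon bound to a double-bonded chain carbon. Among the measured compounds shown here, with no measured step of comparable kind to lean on, the account can only note that compound 1 carries the lowest number and that the change is confined to one aryl group on the chain. In this assay the step from compound 1 to compound 4 is expected to be small, estimated as a 1.0-fold higher number from compound 1 to compound 4 (0.01 log units; within the scatter), in neither direction beyond the scatter. Compound 4 is therefore estimated to give 15000 nM in this assay, with a range from 6000 nM to 40000 nM.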

Compound 4, half-maximal inhibitory concentration: 14400 nM
Compound 4: the middle estimate sits 1.0-fold (0.02 log units) above what was measured, within the range that was stated.
By their numbers in this assay, from the lowest: compounds 4, 1 and 3 (each within the scatter of the next); then compound 2.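

Among the compounds shown here, the step from 2-methoxyphenyl to 4-hydroxyphenyl on a double-bonded chain carbon bound to a double-bonded chain carbon is the first single-place change, and in this assay it comes to a 1.0-fold lower number from compound 1 to compound 4 (0.01 log units; within the scatter). At this place, then, a group with a hydrogen-bond donor can stand in for one without, and the oxygen can sit on a differently numbered ring carbon, with no change beyond the scatter. No measured evidence bears on why the step is this small.

The change of the oxygen group and the change of its ring position arrive together, so the compounds shown cannot separate the two. Going by these compounds, whether 4-aminophenyl or 4-carboxyphenyl at this place would also leave the number within the scatter remains open.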